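This account rests on a few compounds, and the source may have more. Where it says the series, first, only, none or still open, it means among the compounds named here.

Compound 1 `COc1ccc(/C=N/N(C)C(=O)c2ccccc2OC)cc1OC` — 59%
Compound 2 `COc1cccc(C(=O)N(C)/N=C/c2ccc(OC)c(OC)c2)c1` — 69%

In a functional assay on the whole organism (strain A/J) for inhibition, with Mus musculus as the target, with stated times of 1 h and 18 h, at a dose of 100 umol/kg by the oral route (on this read-out higher numbers stand for more inhibition at the one dose given (going by the name of the read-out) and lower numbers for less inhibition), compound 2 gives 69%, the higher of the two measured numbers, though only by a number 10 percentage points higher from compound 1 to compound 2 (within the scatter), a step within the scatter. Compound 3 `COc1ccc(/C=N/N(C)C(=O)c2ccc(OC)c(OC)c2)cc1OC` differs from compound 2 by methoxy in place of hydrogen on an aromatic carbon. Going by the values given here, no measured step adds a methoxy group; the one step known, a number 10 percentage points higher from compound 1 to compound 2 (within the scatter), moved a methoxy group and stayed within the scatter. Nothing in these data therefore points to a step beyond the scatter in this assay. Compound 3 is expected to give about 65%, between 45% and 85%. That estimate means an expected step of a number 4 percentage points lower from compound 2 to compound 3 (within the scatter).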

Compound 3, a percentage reported as inhibition, in the whole organism at one dose (the size of the read-out at that dose, not a potency): 79%
The estimate for compound 3 lay 14 percentage points below the measured number; the measured number falls inside the stated range.
By their numbers in this assay, from the lowest: compounds 1, 2 and 3 (each within the scatter of the next, the first and the last beyond it).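

Compound 3 carries methoxy in place of hydrogen on an aromatic carbon, ortho to a methoxy group and para to a large group, and in this assay this gives a number 10 percentage points higher from compound 2 to compound 3 (within the scatter). The earlier pair only moved a methoxy group, whereas this pair shows an added methoxy group at this place with the step still inside the scatter. No evidence bearing on this result is available.

The compounds shown leave open how an amine or a carboxylic acid at this place would read in this assay, and whether a longer chain there would also stay within the scatter.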